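A few compounds are considered here, and "the series" means these few. Any claim that something is new, unique, unknown or untested is made for them only; others in the source may bear on it.

Working notes on the series. Compound 1 `Cc1cccc(CNC(=O)/C=C/c2ccc(O)c(O)c2)c1` gives 3000 nM in a functional assay on B16 cells (Mus musculus) for inhibition; a lower number here means a stronger inhibitor, a higher number a weaker inhibitor. Compound 2 `Cc1ccc(CNC(=O)/C=C/c2ccc(O)c(O)c2)cc1` differs from it by 4-methylphenyl in place of 3-methylphenyl on a saturated chain carbon bound to an amide-type nitrogen, and in this assay compound 2 gives 3700 nM, the step being a 1.2-fold higher number from compound 1 to compound 2 (0.09 log units; within the scatter). Compound 3 `O=C(/C=C/c1ccc(O)c(O)c1)NCc1cccc(C(F)(F)F)c1` carries the change trifluoromethyl in place of methyl on an aromatic carbon relative to compound 1, and in this assay compound 3 gives 1400 nM, a step of a 2.1-fold lower number from compound 1 to compound 3 (0.33 log units; beyond the scatter). Compound 4 `O=C(/C=C/c1ccc(O)c(O)c1)NCc1ccc(C(F)(F)F)cc1` is not yet measured; it carries trifluoromethyl in place of methyl on an aromatic carbon, the same kind of change, the place now being para to a large group rather than meta to a large group. Going by the values given here, for compound 4 a step of a 2.1-fold lower number from compound 2 to compound 4 (0.31 log units; beyond the scatter) is expected in this assay, resting on the single earlier step of a 2.1-fold lower number from compound 1 to compound 3 (0.33 log units; beyond the scatter), with the shifted place adding uncertainty. Compound 4 is therefore estimated at 1800 nM, probably between 900 nM and 3600 nM.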

Compound 4, half-maximal inhibitory concentration: 1600 nM
The estimate for compound 4 lay 1.1-fold (0.05 log units) above the measured number; the range from low to high includes it.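

In this assay, trifluoromethyl in place of methyl, para to a large group, gives a 2.3-fold lower number from compound 2 to compound 4 (0.36 log units; beyond the scatter). The step keeps its size when the change is carried from one core to the other: the same change on two cores in this assay, a 2.1-fold lower number (0.33 log units; beyond the scatter) from compound 1 to compound 3 and a 2.3-fold lower number (0.36 log units; beyond the scatter) from compound 2 to compound 4, 1.1-fold (0.03 log units) apart, within the scatter of two such steps. Going by these compounds alone, this rests on only two modest steps, on cores that differ in nothing but the place of the group, so it does not show that the step would hold on a core changed elsewhere, nor why the number falls.

Going by these compounds, whether a chlorine, a nitrile or a methoxy group would behave like trifluoromethyl stays open. Also open, on these data alone, is the effect of an amine or a carboxylic acid on the ring, or of a longer chain on the amide nitrogen.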